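Ethyl for Methoxy at the Limit of Inhibition

The compounds below may be only part of what the source reports. "The series", "measured", "known", "first", "only" and "open" are said of these compounds alone.

Measured compounds:
compound 1 `COc1ccc(Nc2ncnc3cc(OC)c(OCCCCC(=O)Nc4ccc(S(N)(=O)=O)cc4)cc23)cc1`: > 40000 nM
compound 2 `COc1cc2ncnc(Nc3ccc(C)cc3)c2cc1OCCCCC(=O)Nc1ccc(S(N)(=O)=O)cc1`: > 40000 nM

In a functional assay on A549 cells (Homo sapiens) for antiproliferative activity, read by MTT assay, with a stated time of 72 h (on this read-out lower numbers stand for stronger inhibition and higher numbers for weaker inhibition), compound 1 gives > 40000 nM, which is a limit of the assay and not a measured number. Compound 2 gives > 40000 nM in this assay, likewise a limit. Going by the values given here, the one measured step, a step that the two limits leave unreadable from compound 1 to compound 2, cannot be sized, since both of its values sit at the limit of > 40000 nM in this assay, at which 2 of the 2 values shown sit. Compound 1 therefore stands only at a limit on the numbers shown, with nothing to place it above or below any neighbour.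

Compound 3 `CCc1ccc(Nc2ncnc3cc(OC)c(OCCCCC(=O)Nc4ccc(S(N)(=O)=O)cc4)cc23)cc1` differs from compound 1 by ethyl in place of methoxy on an aromatic carbon. Among the compounds with values here, the only step that bears on this change is the one from a methoxy to a methyl on the same aromatic carbon, and that step is unreadable. Within the data shown here, no measured step supports a move in either direction in this assay, so compound 3 is expected to remain at the same limit. Compound 3 is estimated at 50000 nM, within 20000 nM to 150000 nM, which corresponds to an expected step that the limit leaves unreadable from compound 1 to compound 3 of no readable size.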

Compound 3, half-maximal inhibitory concentration: 12100 nM
The estimate for compound 3 lay 4.1-fold (0.62 log units) above the measured number; the whole stated range lies above it.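

With ethyl para to a large group, the series gives its first number rather than a limit in this assay, which shows that a change at this one place on the ring can bring activity within the range of the assay. Ethyl in place of methoxy gives an at least 3.3-fold lower number from compound 1 to compound 3 (0.51 log units; beyond the scatter), and the step from methyl to ethyl, a methyl in place of hydrogen on the saturated chain carbon bound to the ring, gives an at least 3.3-fold lower number from compound 2 to compound 3 (0.51 log units; beyond the scatter). Each of these steps starts from a limit and so gives only a minimum size, while the step between the methoxy and methyl compounds cannot be read, and the values that remain at the limit are these: the limit of > 40000 nM in this assay, at which 2 of the 3 values shown sit.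

The compounds shown leave open whether the lower number stops at ethyl or continues with a longer chain such as propyl, and how a chlorine or an amine at the same place would read out. They also leave open how far compound 1 and compound 2 actually stand from each other, as neither has a number in this assay.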